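The source may report more compounds than this note shows. Statements on the series, on what has been measured and on what is new or still open speak of the compounds shown alone.

Of the compounds shown here, three built on one shared core have been tested in an assay for inhibition of MAP kinase-interacting serine/threonine-protein kinase 2 (Homo sapiens), read by luminescence and ADP-Glo, with a stated time of 2 h; a lower number here means a stronger inhibitor, a higher number a weaker inhibitor. Compound 1 `Nc1n[nH]c2cc(-c3ccc(=O)n(Cc4ccccc4F)c3)ccc12` gives 4 nM, and compound 2 `Nc1n[nH]c2cc(-c3ccc(=O)n(Cc4cccc(Cl)c4)c3)ccc12` gives 6 nM; the step of a 1.5-fold higher number from compound 1 to compound 2 (0.18 log units; within the scatter) shows that exchanging one halogenated benzyl group for another changed little. Compound 3 `Nc1cccc(Cn2cc(-c3ccc4cn[nH]c4c3)ccc2=O)c1` gives 84 nM, the highest number of the three, its gaps to compound 2 and to compound 1 both lying beyond the scatter. Compound 4 `O=c1ccc(-c2ccc3cn[nH]c3c2)cn1Cc1cccc(F)c1` differs from compound 3 by fluoro in place of amino on an aromatic carbon. Going by the values given here, no measured step covers this exchange directly; the nearest guide is compound 2, whose 3-chlorobenzyl group also carries a halogen, and compound 3 with its amino group stands far above it. A drop is therefore expected, an 8.4-fold lower number from compound 3 to compound 4 (0.92 log units; beyond the scatter), and compound 4 is estimated at 10 nM, with a range from 4 nM to 30 nM.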

Compound 4, half-maximal inhibitory concentration: 38 nM
Beside the measured number, compound 4's estimate is 3.8-fold (0.58 log units) below it; the measured number lies above the stated range.
By their numbers in this assay, from the lowest: compounds 1 and 2 (each within the scatter of the next); then compound 4; then compound 3.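

Fluoro in place of amino on this aromatic carbon gives a 2.2-fold lower number from compound 3 to compound 4 (0.34 log units; beyond the scatter), so this place on the benzyl group does respond to the exchange, though only modestly. The earlier step compared two halogen-bearing benzyl groups, whereas this one replaces amino, with one hydrogen-bond donor and one acceptor, by fluoro, with neither. Nothing measured here explains the shift. Still open, as far as these compounds go, is where a hydroxyl or a methoxy group at this place would fall, and whether the same exchange would give a similar step on the core of compound 1.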